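Butyl in Place of Isopropyl on the Amide Nitrogen

A few compounds are considered here, and "the series" means these few. Any claim that something is new, unique, unknown or untested is made for them only; others in the source may bear on it.

compound 1, `N[C@H]1CCC[C@@H](N(C(=O)c2ccccc2OCc2ccccc2)C2CCC2)C1`, in an assay on HEK293 cells for inhibition of transient receptor potential cation channel subfamily M member 8 (Homo sapiens), read by FLIPR and calcium flux; on this read-out higher numbers stand for weaker inhibition and lower numbers for stronger inhibition: 1360 nM
compound 2, `CC(C)N(C(=O)c1ccccc1OCc1ccccc1)[C@@H]1CCC[C@H](N)C1`, in this assay: 8780 nM

Compound 2 holds the higher of these two numbers; the step of a 6.5-fold higher number from compound 1 to compound 2 (0.81 log units; beyond the scatter) separates it from compound 1. Compound 3, `CCCCN(C(=O)c1ccccc1OCc1ccccc1)[C@@H]1CCC[C@H](N)C1`, differs from compound 2 by butyl in place of isopropyl on an amide-type nitrogen. Among the measured compounds shown here, only one measured step bears on this change: the move from cyclobutyl to isopropyl raised the number by a modest amount. Adding a carbon to the chain is therefore expected to lower the number in this assay to a modest degree, though no measured pair shows an open chain of this length. Compound 3 is expected to give 4500 nM, between 1500 nM and 14000 nM, an expected step of a 2.0-fold lower number from compound 2 to compound 3 (0.29 log units; within the scatter).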

Compound 3, half-maximal inhibitory concentration: 1400 nM
Compound 3: middle estimate off by 3.2-fold (0.51 log units), on the high side; measured number below the stated range.
By their numbers in this assay, from the lowest: compounds 1 and 3 (each within the scatter of the next); then compound 2.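

With butyl on the amide-type nitrogen, a 6.3-fold lower number from compound 2 to compound 3 (0.80 log units; beyond the scatter) in this assay shows that the weaker reading of the isopropyl compound does not extend to open chains as a whole. The step of a 1.0-fold higher number from compound 1 to compound 3 (0.01 log units; within the scatter) places butyl level with cyclobutyl, so among these three groups isopropyl alone stands apart, and a ring at this place is not needed for the lower number. Nothing given here accounts for this result. From the compounds shown here alone, whether propyl or a longer chain such as hexyl would read like butyl remains open. So does the effect of a branched chain such as tert-butyl at this nitrogen.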